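Series notes: cytotoxicity in the shared chloro-phenyl isoxazoline core

A few compounds are considered here, and "the series" means these few. Any claim that something is new, unique, unknown or untested is made for them only; others in the source may bear on it.

Measured so far in an ADME assay (MDM cells, Homo sapiens) for cytotoxicity, read by resazurin assay, with a stated time of 3 days; a lower number here means a stronger inhibitor, a higher number a weaker inhibitor:
- compound 1 `CSc1nnc(COc2ccccc2C2=NOC(c3ccc(Cl)cc3Cl)C2)n1NC(=O)CCl`: 2.7 ug/mL
- compound 2 `CCCCSc1nnc(COc2ccccc2C2=NOC(c3ccc(Cl)cc3Cl)C2)n1NC(=O)CCl`: 2.8 ug/mL
- compound 3 `CSc1nnc(COc2ccccc2C2=NOC(c3ccc(Cl)cc3Cl)C2)n1NC(=O)c1ccccc1`: 2.2 ug/mL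

Compound 3 has the lowest number of the three, but its gaps to compound 1 and compound 2 are within the scatter, so no order among them can be claimed. Compound 4 `CCCCSc1nnc(COc2ccccc2C2=NOC(c3ccc(Cl)cc3Cl)C2)n1NC(=O)c1ccccc1` differs from compound 3 by propyl in place of hydrogen on a saturated chain carbon bound to a sulfur. The same change has been measured once, as a 1.0-fold higher number from compound 1 to compound 2 (0.02 log units; within the scatter), and the other change in the set, a 1.2-fold lower number from compound 1 to compound 3 (0.09 log units; within the scatter), was also within the scatter. Compound 4 is therefore expected to give 2.3 ug/mL (range 1.2 ug/mL to 4.5 ug/mL). That estimate means a step of a 1.0-fold higher number from compound 3 to compound 4 (0.02 log units; within the scatter), expected to stay within the scatter.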

Compound 4, half-maximal inhibitory concentration: 2.5 ug/mL
For compound 4 the middle estimate is 1.1-fold (0.04 log units) below the measured one, and the stated range covers the measured number.
By their numbers in this assay, from the lowest: compounds 3, 4, 1 and 2 (each within the scatter of the next).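

With phenyl on the carbonyl carbon, methylsulfanyl to butylsulfanyl gives a 1.1-fold higher number from compound 3 to compound 4 (0.06 log units; within the scatter) and so stays within the scatter on a second core: the same change on two cores in this assay, a 1.0-fold higher number (0.02 log units; within the scatter) from compound 1 to compound 2 and a 1.1-fold higher number (0.06 log units; within the scatter) from compound 3 to compound 4, 1.1-fold (0.04 log units) apart, within the scatter of two such steps.
Phenyl in place of chloromethyl on a carbonyl carbon, now read with butylsulfanyl, gives a 1.1-fold lower number from compound 2 to compound 4 (0.05 log units; within the scatter) and also stays within the scatter: the same change on two cores in this assay, a 1.2-fold lower number (0.09 log units; within the scatter) from compound 1 to compound 3 and a 1.1-fold lower number (0.05 log units; within the scatter) from compound 2 to compound 4, 1.1-fold (0.04 log units) apart, within the scatter of two such steps.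
In this assay neither change has yet produced a step beyond the scatter.

As far as these compounds go, whether a longer chain than butyl in the butylsulfanyl group, or an amine in place of phenyl on a carbonyl carbon, would give such a step remains open.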